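A few compounds are considered here, and "the series" means these few. Any claim that something is new, unique, unknown or untested is made for them only; others in the source may bear on it.

Of the compounds shown here, two of a shared core have been measured in a functional assay on PC-12 cells (Rattus norvegicus) for cytotoxicity, read by MTT assay, with stated times of 2 h and 24 h, tested at 1 uM; on this read-out higher numbers stand for a stronger effect at the one concentration tested and lower numbers for a weaker effect. Compound 1, `Cc1ccc(-n2nc(-c3ccc(C(F)(F)F)cc3O)nc2-c2ccccc2O)cc1`, gives 71.5% in this assay. Compound 2, `Oc1cc(C(F)(F)F)ccc1-c1nc(-c2ccccc2O)n(-c2ccc(I)cc2)n1`, gives 70.1%. Within the data shown here, the one step between them, a number 1.4 percentage points lower from compound 1 to compound 2 (within the scatter), is the only measured step, and it is small. Compound 2 thus stands at the lower of the two numbers, with compound 1 near it; the two values cannot be ordered against each other.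

Compound 3, `Oc1cc(C(F)(F)F)ccc1-c1nc(-c2ccccc2O)n(-c2ccccc2F)n1`, is not yet measured. It differs from compound 2 in one place: 2-fluorophenyl in place of 4-iodophenyl on an aromatic nitrogen. Among the measured compounds shown here, no measured step exchanges one of the groups involved here; the only measured step swaps a methyl for an iodo on the same aromatic carbon, and it stayed within the scatter. For the measured compounds named here, the phenyl on the aromatic nitrogen is therefore the only place where a change has been seen, and that change made no difference beyond the scatter. On that basis the step from compound 2 to compound 3 in this assay is expected to be about a number 2.1 percentage points lower from compound 2 to compound 3 (within the scatter), with no direction beyond the scatter anticipated. Compound 3 is expected to give 68%, between 55% and 80%.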

Compound 3, a percentage reported as activity, at one concentration (the size of the read-out at that concentration, not a potency): 63.4%
The estimate for compound 3 lay 4.6 percentage points above the measured number; the measured number falls inside the stated range.
By their numbers in this assay, from the lowest: compounds 3, 2 and 1 (each within the scatter of the next).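

Among these compounds, compound 3 places a different group on the aromatic nitrogen, 2-fluorophenyl, where the earlier compounds showed only the exchange of 4-methylphenyl for 4-iodophenyl. In this assay the two new steps, a number 6.7 percentage points lower from compound 2 to compound 3 (within the scatter) and a number 8.1 percentage points lower from compound 1 to compound 3 (within the scatter) both stay within the scatter, so moving the substituent to another place on this phenyl and exchanging it for fluorine gives no difference that can be read, and compounds 1, 2 and 3 cannot be ordered against one another. No measurement shown here offers an explanation for these numbers.

All three compounds keep a substituted phenyl on this nitrogen and leave the rest of the shared core unchanged, so the result speaks only to exchanges among such groups; 2-fluorophenyl and 4-iodophenyl also have the same count of heavy atoms. From the compounds shown here alone, what an amine, a carboxylic acid or a longer chain would give at this position stays open, as does the effect of exchanging the trifluoromethyl group or either hydroxyl group elsewhere on the core.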